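The compounds below may be only part of what the source reports. "The series", "measured", "known", "first", "only" and "open" are said of these compounds alone.

Measured in a functional assay on DU-145 cells (Homo sapiens) for antiproliferative activity, read by MTT assay, with a stated time of 48 h; on this read-out higher numbers stand for weaker inhibition and lower numbers for stronger inhibition:
Compound 1 `Brc1ccc(-c2nnc(-c3cn4ccccc4n3)o2)cc1`: > 50000 nM, a limit of the assay
Compound 2 `Cc1cccn2cc(-c3nnc(-c4ccccc4)o3)nc12`: 21800 nM
Compound 3 `Cc1cccn2cc(-c3nnc(-c4ccc(Br)cc4)o3)nc12`: 38900 nM

Among the measured compounds shown here, compound 3, at 38900 nM, and compound 2, at 21800 nM, are the only true numbers here, and they lie within the scatter of each other. The unmeasured compound 4 `Cc1cccn2cc(-c3nnc(-c4ccccc4I)o3)nc12` carries 2-iodophenyl in place of 4-bromophenyl on an aromatic carbon. For the measured compounds named here, two measured steps bear on this change. Bromo in place of hydrogen gave a 1.8-fold higher number from compound 2 to compound 3 (0.25 log units; within the scatter). Methyl in place of hydrogen gave an at least 1.2-fold lower number from compound 1 to compound 3 (0.10 log units; that floor lies within the scatter), a floor that rests on (the limit of > 50000 nM in this assay, at which 1 of the 3 values shown sits). Going by the values given here, no measured compound carries iodine, so this exact change is untested. The expected change is no larger than the scatter: a 1.3-fold lower number from compound 3 to compound 4 (0.11 log units; within the scatter). Compound 4 is estimated at 30000 nM, with an expected range of 12000 nM to 50000 nM.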

Compound 4, half-maximal inhibitory concentration: 31500 nM
For compound 4 the middle estimate is 1.1-fold (0.02 log units) below the measured one, and the stated range covers the measured number.
By their numbers in this assay, from the lowest: compounds 2, 4 and 3 (each within the scatter of the next). At a limit, above all of these: compound 1.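

In this assay, 2-iodophenyl in place of 4-bromophenyl gives a 1.2-fold lower number from compound 3 to compound 4 (0.09 log units; within the scatter), and iodo in place of hydrogen gives a 1.4-fold higher number from compound 2 to compound 4 (0.16 log units; within the scatter). Phenyl, 4-bromophenyl and 2-iodophenyl at this place thus all lie within the scatter of one another, now including a different halogen at a different ring position. Nothing available explains these values. Halogen and ring position changed together in the step from compound 3, so their separate contributions remain unknown. Going by these compounds, whether an amine or a carboxylic acid on the phenyl ring would shift the number beyond the scatter also remains open.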